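The source may report more compounds than this note shows. Statements on the series, on what has been measured and on what is new or still open speak of the compounds shown alone.

Compound 1 `O=c1[nH]c(=O)n([C@H]2C[C@H](O)[C@@H](CO)O2)cc1C#CC#CCO` and compound 2 `O=c1[nH]c(=O)n([C@H]2C[C@H](O)[C@@H](CO)O2)cc1C#CC#CCC1CCCC1` share one core and differ at a single place. In an ADME assay on HEL cells (Homo sapiens), read by cell counting, with a stated time of 3 days (on this read-out higher numbers stand for lower toxicity in this test and lower numbers for higher toxicity in this test), compound 1 gives only a limit, > 100000 nM. In this assay, going by the values given here, compound 2 gives 89000 nM, the only full number measured here. The step of an at least 1.1-fold lower number from compound 1 to compound 2 (0.05 log units; that floor lies within the scatter) lies within the scatter. Compound 3 `O=c1[nH]c(=O)n([C@H]2C[C@H](O)[C@@H](CO)O2)cc1C#CC#CC1CC1` differs from compound 2 by cyclopropyl in place of cyclopentylmethyl on a triple-bonded carbon. Among the compounds with values here, since the only measured step, an at least 1.1-fold lower number from compound 1 to compound 2 (0.05 log units; that floor lies within the scatter), altered the same side chain without a clear effect, compound 3 is expected to show no step beyond the scatter, a 1.0-fold higher number from compound 2 to compound 3 (0.00 log units; within the scatter). The estimate for compound 3 is 90000 nM, between 40000 nM and 200000 nM.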

Compound 3, half-maximal cytotoxic concentration: > 100000 nM
Compound 3 was reported as a limit; the forecaster's own chance of this, stated with the estimate: 40%; middle value at least 1.1-fold (0.04 log units) away from the limit.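

Putting cyclopropyl in place of cyclopentylmethyl on a triple-bonded carbon gives an at least 1.1-fold higher number from compound 2 to compound 3 (0.05 log units; that floor lies within the scatter), so in this assay this change shows no step beyond the scatter. Compound 1 and compound 3 each give a limit rather than a number, and the step between them cannot be read: the limit of > 100000 nM in this assay, at which 2 of the 3 values shown sit.

So far, hydroxymethyl, cyclopentylmethyl and cyclopropyl at this place show no readable step beyond the scatter. As far as these compounds go, whether an amine, a carboxylic acid or a longer chain there would lower the number clearly stays open.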